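The source may report more compounds than this note shows. Statements on the series, on what has been measured and on what is new or still open speak of the compounds shown alone.

In a functional assay on BaF3 cells (Mus musculus) for antiproliferative activity, read by CCK-8 assay and cell counting, with a stated time of 76 h (on this read-out lower numbers stand for stronger inhibition and higher numbers for weaker inhibition), compound 1 `COc1cc2nccc(Oc3ccc(Nc4nn(C)cc4C(=O)NC4CCCCCCC4)cc3)c2cc1C(N)=O`, with cyclooctyl on the amide-type nitrogen, gives 3210 nM. Compound 2 `COc1cc2nccc(Oc3ccc(Nc4nn(C)cc4C(=O)NCC4CCCO4)cc3)c2cc1C(N)=O` gives > 10000 nM, which is a limit of the assay and not a number. This places compound 2 at the limit of > 10000 nM in this assay, at which 1 of the 2 values shown sits.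

The next change leads to compound 3 `COc1cc2nccc(Oc3ccc(Nc4nn(C)cc4C(=O)NCC4CCCCC4)cc3)c2cc1C(N)=O`. It is cyclohexyl in place of oxolan-2-yl on a saturated chain carbon bound to an amide-type nitrogen, with cyclohexyl in place of oxolan-2-yl on a saturated chain carbon bound to an amide-type nitrogen, so (oxolan-2-yl)methyl becomes cyclohexylmethyl.

Going by the values given here, only one measured step bears on this: an at least 3.1-fold higher number from compound 1 to compound 2 (0.49 log units; beyond the scatter), with (oxolan-2-yl)methyl in place of cyclooctyl. As far as these compounds go, its full size is unknown, since one end is a limit. Compound 3 returns to a ring of carbon only, as in compound 1 at 3210 nM, so a move to a lower number in this assay is expected, of at least modest size. With a single step as the guide, this expectation is loose, and a reading at the limit remains possible.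

The estimated step is an at least 2.2-fold lower number from compound 2 to compound 3 (0.34 log units; beyond the scatter). For compound 3, the expected value is 4500 nM, with an estimated range of 1500 nM to 10000 nM.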

Compound 3, half-maximal inhibitory concentration: > 10000 nM
Compound 3: a limit, no number (the forecaster's own chance of this, stated with the estimate: 30%); at least 2.2-fold (0.34 log units) between middle value and limit.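

Working notes: a ring of carbon only on this saturated chain carbon does not by itself bring a measurable value, since in this assay compound 3 gives > 10000 nM, which is a limit of the assay and not a number. Replacing cyclooctyl on the amide-type nitrogen with cyclohexylmethyl gives an at least 3.1-fold higher number from compound 1 to compound 3 (0.49 log units; beyond the scatter), so among the compounds shown, only cyclooctyl gives a number, and both groups tried on the saturated chain carbon fall short of it. The step from compound 2 to compound 3 cannot be read, and the order of oxolan-2-yl and cyclohexyl at this place stays unknown, as both ends are limits: the limit of > 10000 nM in this assay, at which 2 of the 3 values shown sit.

Compound 1 and compound 3 differ in ring size and in the added chain carbon together, so the compounds shown do not say which of the two goes with the loss. Also open, as far as these compounds go, is whether cycloheptyl set straight on the amide-type nitrogen, or a longer chain ending in an amine, would give a number near that of compound 1, at 3210 nM, or a stronger one.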